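The source may hold more compounds than are shown below. What is called first, only, known or untested is meant among the compounds shown, and "the series" means these compounds.

Working notes on the series. The shared core of compound 1 `CN1CCN(c2ccn3c(-c4ccc(NC(=O)c5ccc([N+](=O)[O-])o5)cc4)cnc3c2)CC1` carries a saturated amine ring on an aromatic carbon; in a functional assay on MGC-803 cells (Homo sapiens) for antiproliferative activity, read by CCK-8 assay, with a stated time of 72 h (a lower number here means a stronger inhibitor, a higher number a weaker inhibitor), compound 1 gives 1580 nM. Compound 2 `CC1(O)CCN(c2ccn3c(-c4ccc(NC(=O)c5ccc([N+](=O)[O-])o5)cc4)cnc3c2)CC1` differs from it only in that ring, and in this assay compound 2 gives 3100 nM. The step of a 2.0-fold higher number from compound 1 to compound 2 (0.29 log units; within the scatter) is the only one measured so far, and it lies within the scatter, so the two numbers are not distinguished; compound 2 stands beside compound 1 without an order between them.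

Compound 3 `O=C(Nc1ccc(-c2cnc3cc(N4CCCC4)ccn23)cc1)c1ccc([N+](=O)[O-])o1` is the next member. The change from compound 2 is pyrrolidin-1-yl in place of 4-hydroxy-4-methylpiperidin-1-yl on an aromatic carbon. Among the compounds with values here, no measured step exchanges one saturated amine ring for another of a different ring size, so the step from compound 1 to compound 2 is the only comparison that bears on it, and that step stayed within the scatter. On that basis no movement beyond the scatter is expected in this assay for compound 3, in either direction, and the step is estimated at a 1.2-fold lower number from compound 2 to compound 3 (0.09 log units; within the scatter).

Compound 3 is therefore expected in this assay near 2500 nM, with a range from 1000 nM to 6300 nM.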

Compound 3, half-maximal inhibitory concentration: 1150 nM
Beside the measured number, compound 3's estimate is 2.2-fold (0.34 log units) above it, and the stated range covers the measured number.
By their numbers in this assay, from the lowest: compounds 3, 1 and 2 (each within the scatter of the next, the first and the last beyond it).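

Notes on this position: in this assay, the exchange of the saturated amine ring now gives a step beyond the scatter, a modest one (a 2.7-fold lower number from compound 2 to compound 3 (0.43 log units; beyond the scatter)), whereas the only earlier comparison stayed within it. The other new comparison, pyrrolidin-1-yl in place of 4-methylpiperazin-1-yl, stays within the scatter (a 1.4-fold lower number from compound 1 to compound 3 (0.14 log units; within the scatter)), so compound 1 is not separated from compound 3 or from compound 2, and only the outer pair of the three is distinguished. Nothing available bears on a cause for the step from compound 2 to compound 3.

That step changes ring size and removes the hydroxy and methyl groups in a single exchange, so the compounds shown do not divide it among those changes; unsubstituted piperidin-1-yl would stand directly between compound 2 and compound 3 on that question. Within the data shown here, also open is whether the same place accepts groups outside the saturated amine rings, such as an open-chain dimethylamino group or a carboxylic acid, and whether any of them would move the number further than the single modest step seen so far.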